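A few compounds are considered here, and "the series" means these few. Any claim that something is new, unique, unknown or untested is made for them only; others in the source may bear on it.

Three compounds built on a shared core have been examined in a functional assay on MDA-MB-231 cells (Homo sapiens) for antiproliferative activity, read by MTT assay, with a stated time of 72 h (a higher number here means a weaker inhibitor, a lower number a stronger inhibitor), and all three return only a limit. Compound 1 `CC(=O)Nc1ccc(S(=O)(=O)Nc2cccc(-c3nc(-c4ccc(NC(=O)c5cccnc5)cc4Cl)no3)c2)cc1C` gives > 10000 nM, which is a limit of the assay rather than a measured number. Compound 2 `O=C(Nc1ccc(-c2noc(-c3cccc(NS(=O)(=O)c4ccc(NC(=O)N5CCCCC5)cc4)c3)n2)c(Cl)c1)c1cccnc1` gives > 10000 nM, again a limit. Compound 3 `NS(=O)(=O)c1ccc(NC(=O)Nc2cccc(-c3nc(-c4ccc(NC(=O)c5cccnc5)cc4Cl)no3)c2)cc1` likewise gives > 10000 nM, a limit and not a number. Compound 3 therefore stands exactly where every value shown stands, namely at the limit of > 10000 nM in this assay, at which 3 of the 3 values shown sit, and no ordering among the three compounds can be drawn from these figures. Compound 4 `NS(=O)(=O)Nc1ccc(NC(=O)Nc2cccc(-c3nc(-c4ccc(NC(=O)c5cccnc5)cc4Cl)no3)c2)cc1` has not yet been measured in this assay. It differs from compound 3 in one place: sulfamoylamino in place of sulfamoyl on an aromatic carbon. Within the data shown here, no step between measured compounds exists to gauge how large an effect this change might have, and the three limits offer nothing to compare against. Compound 4 is expected to remain at the limit as well. The step is estimated as a step that the limit leaves unreadable from compound 3 to compound 4, which means no change beyond the usual scatter. The estimate for compound 4 is 20000 nM, with a range from 8000 nM to 50000 nM.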

Compound 4, half-maximal inhibitory concentration: 8900 nM
Beside the measured number, compound 4's estimate is 2.2-fold (0.35 log units) above it; low and high end bracket the measured number.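

In this assay, among these compounds, compound 4 gives 8900 nM, the only actual number among the four compounds, so this position on the shared core can yield a readable value. Sulfamoylamino in place of sulfamoyl, on an aromatic carbon para to a large group, gives an at least 1.1-fold lower number from compound 3 to compound 4 (0.05 log units; that floor lies within the scatter), and that floor alone shows no change beyond the usual scatter. The full size of the step cannot be read, because compound 3 stands at a limit and not at a number: the limit of > 10000 nM in this assay, at which 3 of the 4 values shown sit.

From the compounds shown here alone, what a carboxylic acid or a simple amine would give at this position in this assay remains open. Also open, going by these compounds, is whether sulfamoylamino would give a number in place of the limit on the sulfonamide-linked cores of compound 1 and compound 2.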